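The source may report more compounds than this note shows. Statements on the series, on what has been measured and on what is new or still open speak of the compounds shown alone.

In a functional assay on L929 cells (Mus musculus) for inhibition, read by MTT assay, with a stated time of 5 days (on this read-out lower numbers stand for stronger inhibition and higher numbers for weaker inhibition), compound 3 `COc1ccc(NCc2ccccc2)cc1` gives 30 ug/mL, which stands highest of the two numbers shown, though the gap to compound 1 `COc1ccc(N(Cc2ccccc2OC)CC(C)C)cc1`, giving 15 ug/mL, lies within the scatter. Compound 2 `COc1ccc(N(Cc2ccccc2)Cc2ccccc2OC)cc1` reaches only a limit of the assay, > 40 ug/mL, as recorded in the limit of > 40 ug/mL in this assay, at which 1 of the 3 values shown sits. Compound 4 `COc1ccc(NCc2ccccc2OC)cc1` differs from compound 3 by methoxy in place of hydrogen on an aromatic carbon. For the measured compounds named here, no measured step tests this change on its own: the single measured step, an at least 2.6-fold higher number from compound 1 to compound 2 (0.42 log units; beyond the scatter), swaps a different group, and compounds 1 and 2 both already carry the methoxy. A step within the scatter is therefore expected, a 1.2-fold lower number from compound 3 to compound 4 (0.08 log units; within the scatter). Compound 4 is estimated at 25 ug/mL, with a range from 10 ug/mL to 60 ug/mL.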

Compound 4, half-maximal inhibitory concentration: 25 ug/mL
For compound 4 middle estimate and measured number coincide at the digits printed, and the stated range covers the measured number.
By their numbers in this assay, from the lowest: compounds 1, 4 and 3 (each within the scatter of the next). At a limit, above all of these: compound 2.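

In this assay, methoxy in place of hydrogen on an aromatic carbon, ortho to a large group, now has a test of its own, and a 1.2-fold lower number from compound 3 to compound 4 (0.08 log units; within the scatter) shows no change that can be told from the scatter. The substituent on the nitrogen is also tested: hydrogen in place of isobutyl gives a 1.7-fold higher number from compound 1 to compound 4 (0.22 log units; within the scatter), and hydrogen in place of benzyl gives an at least 1.6-fold lower number from compound 2 to compound 4 (0.20 log units; that floor lies within the scatter). That last step is only a floor: the limit of > 40 ug/mL in this assay, at which 1 of the 4 values shown sits.

As far as these compounds go, whether a hydroxyl, an amine or a carboxylic acid on this aromatic carbon would give a step beyond the scatter stays open.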